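The source may hold more compounds than are shown below. What is called first, only, known or untested is meant among the compounds shown, and "the series" means these compounds.

The compounds here share one core, carried by compound 1 `Nc1nc(NC2CCCCC2)c2ncn(/C=C3/CC3(CO)CO)c2n1`, and the question is how much of each is tolerated by the cells. In an ADME assay on CCRF-HSB-2 cells (Homo sapiens) for cytotoxicity, with a stated time of 7 days (a higher number here means that more compound is tolerated, a lower number that less compound is tolerated), compound 1 gives > 20000 nM, which is a limit of the assay rather than a number. Compound 2 `Nc1nc(NC2CC2)c2ncn(/C=C3/CC3(CO)CO)c2n1` gives > 20000 nM in this assay, again a limit. Compound 3 `CCCCCOc1nc(N)nc2c1ncn2/C=C1/CC1(CO)CO` gives > 20000 nM in this assay, likewise a limit. Between these three the steps cannot be read: the step that the two limits leave unreadable from compound 1 to compound 2, the step that the two limits leave unreadable from compound 1 to compound 3 and the step that the two limits leave unreadable from compound 2 to compound 3 are each left unreadable by the two limits. Going by the values given here, the one thing the three values show together is the limit of > 20000 nM in this assay, at which 3 of the 3 values shown sit, so all changes at that position of the core so far left the compounds without measurable cytotoxicity.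

Compound 4 `Nc1nc(SC2CCCC2)c2ncn(/C=C3/CC3(CO)CO)c2n1` differs from compound 1 in one place: cyclopentylsulfanyl in place of cyclohexylamino on an aromatic carbon. Among the compounds with values here, none of the measured steps gives a readable size for such a change, so no shift beyond the scatter can be argued for either direction. Given that compound 1 sits at the limit > 20000 nM, compound 4 is expected to stay there too, and the step that the limit leaves unreadable from compound 1 to compound 4 is estimated to be about nothing. Compound 4 is therefore expected to give roughly 30000 nM in this assay, within 12000 nM to 80000 nM.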

Compound 4, half-maximal cytotoxic concentration: 91000 nM
Estimate against measurement, compound 4: 3.0-fold (0.48 log units) below; the whole stated range lies below it.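

Compound 4 has a measured value in this assay, yet the steps to it from compound 1, compound 2 and compound 3 cannot be read, as each of those three stands at a limit of the assay. The compounds shown leave open how far compound 1, compound 2 and compound 3 actually lie from compound 4.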